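The source may hold more compounds than are shown below. What is called first, only, known or untested is meant among the compounds shown, and "the series" means these compounds.

Measured so far in a functional assay on A-431 cells (Homo sapiens) for cytotoxicity, read by MTT assay, with a stated time of 48 h; on this read-out lower numbers stand for stronger inhibition and higher numbers for weaker inhibition: compound 1 `C/C=C/C=C/C(=O)N[C@H](C(=O)NCCCCCCCC)[C@@H](C)O` gives 58200 nM; compound 2 `C/C=C/C=C/C(=O)N[C@H](C(=O)NCCCCCCCCCCCC)[C@@H](C)O` gives 171000 nM; compound 3 `CCCCCCCCCCCCCCNC(=O)[C@@H](NC(=O)c1nccc2ccccc12)[C@@H](C)O` gives 23000 nM.

Compound 3 holds the lowest number of the three, and its gaps to compound 1 and to compound 2 both lie beyond the scatter. Compound 4 `C/C=C/C=C/C(=O)N[C@H](C(=O)NCCCCCCCCCCCCCC)[C@@H](C)O` differs from compound 3 by penta-1,3-dien-1-yl in place of isoquinolin-1-yl on a carbonyl carbon. Among the measured compounds shown here, no measured pair covers that exchange of acyl group, so the expectation rests on indirect evidence. For the measured compounds named here, the one measured step, a 2.9-fold higher number from compound 1 to compound 2 (0.47 log units; beyond the scatter), shows the longer chain on the penta-1,3-dien-1-yl amide giving the higher number, and compound 4 carries the longest chain of all on that same amide. The author therefore expects a clearly higher number, an 11-fold higher number from compound 3 to compound 4 (1.04 log units; beyond the scatter). For compound 4 the estimate is 250000 nM, with a range from 100000 nM to 600000 nM.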

Compound 4, half-maximal inhibitory concentration: > 200000 nM
Compound 4 gave a limit, no number; the forecaster's own chance of this, stated with the estimate: 20%; the middle value is on the limit's open side.
By their numbers in this assay, from the lowest: compound 3; then compound 1; then compound 2. At a limit, above all of these: compound 4.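

Compound 4 gives only a limit, not a number: the limit of > 200000 nM in this assay, at which 1 of the 4 values shown sits. Placing penta-1,3-dien-1-yl in place of isoquinolin-1-yl on the carbonyl carbon gives an at least 8.6-fold higher number from compound 3 to compound 4 (0.93 log units; beyond the scatter), the first reading of this exchange with the chain held the same. On the chain, an at least 3.4-fold higher number from compound 1 to compound 4 (0.53 log units; beyond the scatter) goes the same way as the earlier step, whereas an at least 1.1-fold higher number from compound 2 to compound 4 (0.06 log units; that floor lies within the scatter) has a floor within the scatter, so the limit leaves that pair unresolved.

The compounds shown leave open how isoquinolin-1-yl behaves on the shorter chains of compound 1 and compound 2. They also leave open what a phenyl or a pyridine on that carbonyl carbon would give.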